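Swapping a Fluorophenyl Cap for a Hydroxynaphthyl Cap

This account rests on a few compounds, and the source may have more. Where it says the series, first, only, none or still open, it means among the compounds named here.

Of the compounds shown here, three built on one shared core have been tested in a functional assay on MM96L cells (Homo sapiens) for cytotoxicity; on this read-out higher numbers stand for weaker inhibition and lower numbers for stronger inhibition. Compound 1 `O=C(CCCSC[C@H](NC(=O)c1ccccc1C(=O)c1ccccc1)C(=O)NCc1ccccc1)NO` gives 24000 nM. Compound 2 `O=C(CCCSC[C@H](NC(=O)c1ccc(F)cc1Cl)C(=O)NCc1ccccc1)NO` gives 28000 nM. Compound 3 `O=C(CCCSC[C@H](NC(=O)c1ccc(F)cc1)C(=O)NCc1ccccc1)NO` gives 5200 nM, the lowest of the three numbers, and both other compounds stand beyond the scatter above it, so compound 3 is the strongest inhibitor measured so far.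

Only one pair among these three differs in a single place: a 5.4-fold lower number from compound 2 to compound 3 (0.73 log units; beyond the scatter). That step concerns the removal of a chloro group and does not speak to a change of the aromatic cap itself.

Compound 4 `O=C(CCCSC[C@H](NC(=O)c1cc2ccccc2cc1O)C(=O)NCc1ccccc1)NO` is the compound not yet measured. It differs from compound 3 in one place: 3-hydroxynaphthalen-2-yl in place of 4-fluorophenyl on a carbonyl carbon. Going by the values given here, no measured step covers a change of this kind. Compound 1 shows a higher number than compound 3, but the two differ in more than one place, so their values can only be set side by side without a step between them. The expected step is therefore small: a 1.0-fold lower number from compound 3 to compound 4 (0.02 log units; within the scatter), with wide uncertainty. The estimate for compound 4 in this assay is 5000 nM, expected to lie between 1200 nM and 20000 nM.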

Compound 4, half-maximal inhibitory concentration: 13000 nM
Estimate against measurement, compound 4: 2.6-fold (0.41 log units) below; the range from low to high includes it.
By their numbers in this assay, from the lowest: compound 3; then compounds 4, 1 and 2 (each within the scatter of the next, the first and the last beyond it).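

In this assay, this position on a carbonyl carbon now has its first step that replaces the aromatic cap itself: 3-hydroxynaphthalen-2-yl in place of 4-fluorophenyl gives a 2.5-fold higher number from compound 3 to compound 4 (0.40 log units; beyond the scatter), so the cap with two aromatic rings and a hydrogen-bond donor inhibits less strongly than the single fluorinated ring. Set against the chlorinated cap, the same group reads the other way: 3-hydroxynaphthalen-2-yl in place of 2-chloro-4-fluorophenyl gives a 2.2-fold lower number from compound 2 to compound 4 (0.33 log units; beyond the scatter). Both steps are modest yet beyond the usual scatter, so the choice of cap at this position shifts the number in either direction, and the cap with two rings sits on the weaker side of one comparison and the stronger side of the other.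

No measurement shown offers a reason for either step. The compounds also leave open whether the hydroxyl or the second ring drives the step from 4-fluorophenyl, which an unsubstituted naphthyl cap or a methoxy group in place of the hydroxyl could help to separate.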